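Halogen exchange on the benzamide ring of compound 2

A few compounds are considered here, and "the series" means these few. Any claim that something is new, unique, unknown or untested is made for them only; others in the source may bear on it.

Among the measured compounds shown here, compound 2 `NC(=O)c1c(NC(=O)c2ccccc2Cl)sc2c1CCN(C(=S)Nc1ccccc1C(F)(F)F)C2` holds the lower of the two numbers so far: in a functional assay on MKN-74 cells (Homo sapiens) for antiproliferative activity, with a stated time of 24 h (on this read-out lower numbers stand for stronger inhibition and higher numbers for weaker inhibition), compound 2 gives 1870 nM, while compound 1 `NC(=O)c1c(NC(=O)c2ccccc2Cl)sc2c1CCN(C(=S)Nc1ccccc1)C2` gives 15600 nM. For the measured compounds named here, the only measured step, an 8.3-fold lower number from compound 1 to compound 2 (0.92 log units; beyond the scatter), is a different change at a different place and does not bear on the exchange considered here. Compound 3 `NC(=O)c1c(NC(=O)c2ccccc2I)sc2c1CCN(C(=S)Nc1ccccc1C(F)(F)F)C2` differs from compound 2 by iodo in place of chloro on an aromatic carbon. Going by the values given here, no measured pair touches that position, so the data give no ground to expect a step beyond the scatter in this assay in either direction, and the expectation is simply that the number stays near that of compound 2. Relative to compound 2, compound 3 is expected to show a 1.0-fold higher number from compound 2 to compound 3 (0.01 log units; within the scatter), a step within the scatter. The estimate for compound 3 in this assay is 1900 nM, with a range from 600 nM to 6000 nM.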

Compound 3, half-maximal inhibitory concentration: 14200 nM
For compound 3 the middle estimate is 7.5-fold (0.87 log units) below the measured one, outside the stated range (above it).
By their numbers in this assay, from the lowest: compound 2; then compounds 3 and 1 (each within the scatter of the next).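

The position on the benzamide ring is sensitive to the halogen it carries: on this aromatic carbon, ortho to a large group, iodo in place of chloro gives a 7.6-fold higher number from compound 2 to compound 3 (0.88 log units; beyond the scatter) in this assay. Among the compounds shown here, until now, the only step read lay elsewhere in the molecule, so this is the first sign that this ring also moves the number, with chloro giving the stronger inhibition of the two halogens. The data offer no explanation for the size of this step.

From the compounds shown here alone, whether the number follows a trend across the halogens remains open, as fluoro and bromo at this carbon would be needed to show it. Also open, going by these compounds, are how an amine or a carboxylic acid would read here, and whether the exchange gives a similar step on the core of compound 1, which lacks trifluoromethyl.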